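Adding a fluoro group to compound 1

The source may hold more compounds than are shown below. What is called first, only, known or untested is meant among the compounds shown, and "the series" means these compounds.

- Compound 1 `CN1C(=O)C(O)(Cc2nnn[nH]2)c2ccccc21` gives 45500 nM in a functional assay on PA-1 cells (Homo sapiens) for antiproliferative activity, read by MTT assay, with a stated time of 48 h; on this read-out higher numbers stand for weaker inhibition and lower numbers for stronger inhibition
- Compound 2 `CCN1C(=O)C(O)(Cc2nnn[nH]2)c2ccccc21` gives > 100000 nM as a limit of the assay, not a number

Within the data shown here, compound 1 holds the only exact number so far, and the one other result is a limit. That makes compound 1 the natural reference point for compound 3 `CN1C(=O)C(O)(Cc2nnn[nH]2)c2cc(F)ccc21`, which keeps the same core and differs in one place: fluoro in place of hydrogen on an aromatic carbon.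

Among the measured compounds shown here, only one measured step is available, and it is an at least 2.1-fold higher number from compound 1 to compound 2 (0.34 log units; beyond the scatter). That step is methyl in place of hydrogen on a saturated chain carbon bound to an amide-type nitrogen in a ring. It shows that a small change to compound 1 can register in this assay, but it lies in a different part of the molecule. For the measured compounds named here, no measured step involves the aromatic carbon, so the direction remains open, and no clear shift is expected.

The estimated change is a 1.1-fold lower number from compound 1 to compound 3 (0.06 log units; within the scatter), with wide uncertainty.

For compound 3 the estimated value is 40000 nM, with an expected range from 15000 nM to 100000 nM.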

Compound 3, half-maximal inhibitory concentration: > 100000 nM
Compound 3: a limit, no number; the forecaster's own chance of this, stated with the estimate: 20%; middle value at least 2.5-fold (0.39 log units) away from the limit.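

In this assay, this aromatic carbon proves sensitive to change: fluoro in place of hydrogen, a swap of a single heavy atom, gives an at least 2.1-fold higher number from compound 1 to compound 3 (0.34 log units; beyond the scatter). Among these compounds, until now, the only measured change to compound 1 was on the chain at the ring nitrogen, so this result shows that activity also weakens with a change in a different part of the molecule, on the six-membered aromatic ring. The real size of the step cannot be read, because compound 3 gives only a limit of the assay and not a number, the same ceiling reached by compound 2: the limit of > 100000 nM in this assay, at which 2 of the 3 values shown sit.

The compounds shown leave open whether this weakening is specific to fluoro or would also follow from another group on the same carbon, such as chloro, methoxy or an amine. They also leave open whether any group on this ring could bring a number lower than that of compound 1, and whether the other aromatic carbons respond as this one does.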